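This account rests on a few compounds, and the source may have more. Where it says the series, first, only, none or still open, it means among the compounds named here.

Three measured compounds share one core and differ only in the group hanging from the carbon that is double-bonded to nitrogen: compound 1 `CN(C)C(=O)C[C@H](CSc1ccccc1)Nc1c(C(=O)N/N=C/c2ccccc2F)cnc2c(C(F)(F)F)cccc12`, compound 2 `CN(C)C(=O)C[C@H](CSc1ccccc1)Nc1c(C(=O)N/N=C/c2cc(F)ccc2O)cnc2c(C(F)(F)F)cccc12` and compound 3 `COc1ccc(/C=N/NC(=O)c2cnc3c(C(F)(F)F)cccc3c2N[C@@H](CSc2ccccc2)CC(=O)N(C)C)c(F)c1`. In an ADME assay on Vero cells (Chlorocebus sabaeus) for cytotoxicity, read by MTT assay, with a stated time of 72 h (on this read-out lower numbers stand for stronger inhibition and higher numbers for weaker inhibition), compound 1 gives > 62.5 ug/mL, which is a limit of the assay rather than a number. For compound 2 this assay reports "not determined" (no result reported). Compound 3 stands at "not determined" (no result reported) in this assay, so it has no number of its own to start from. The only footing in the series is the limit of > 62.5 ug/mL in this assay, at which 1 of the 3 values shown sits.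

Compound 4 `CCCCCCCC/C=N/NC(=O)c1cnc2c(C(F)(F)F)cccc2c1N[C@@H](CSc1ccccc1)CC(=O)N(C)C` is the next step from compound 3. The change is octyl in place of 2-fluoro-4-methoxyphenyl on a carbon with a double bond to nitrogen, that is, a flexible eight-carbon chain takes the place of a substituted aromatic ring while the rest of the molecule is kept. Within the data shown here, with no measured step between any two compounds in this assay, there is nothing to say how large a move this swap usually brings; the expectation is therefore for no difference beyond the scatter, with compound 4 most likely also sitting at the same limit as the one measured compound. Compound 4 is estimated at 50 ug/mL in this assay, within a range from 15 ug/mL to 125 ug/mL.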

Compound 4, half-maximal inhibitory concentration: > 62.5 ug/mL
Compound 4: no number, only a limit; the forecaster's own chance of this, stated with the estimate: 65%; middle value at least 1.2-fold (0.09 log units) from the limit.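

In this assay compound 4 gives > 62.5 ug/mL, which is a limit of the assay and not a number. Among these compounds, compound 1 also has only a limit, so no step between compound 1 and compound 4 can be read. The only footing remains a shared one: the limit of > 62.5 ug/mL in this assay, at which 2 of the 4 values shown sit. The compounds shown leave open whether changing the group on the carbon double-bonded to nitrogen alters cytotoxicity at all.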